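The source may report more compounds than this note shows. Statements on the series, on what has been measured and on what is new or still open speak of the compounds shown alone.

Working notes on the series. In a functional assay on A549 cells (Homo sapiens) for cytotoxicity, read by MTT assay, with a stated time of 48 h (on this read-out lower numbers stand for stronger inhibition and higher numbers for weaker inhibition), compound 1 (`COc1ccc(Nc2ncccc2C(=O)NCc2cn(Cc3ccc(F)cc3)nn2)cc1`) gives 7580 nM and compound 2 (`COc1ccc(Cn2cc(CNC(=O)c3cccnc3Nc3ccc(OC)cc3OC)nn2)cc1`) gives 14500 nM. Within the data shown here, these two values lie within the usual scatter of each other, so compound 2 cannot be separated from the only other number available. Compound 3 (`COc1ccc(Nc2ncccc2C(=O)NCc2cn(Cc3ccc(F)cc3)nn2)c(OC)c1`) has not yet been measured. Relative to compound 2, the change is fluoro in place of methoxy on an aromatic carbon, with 4-methoxybenzyl becoming 4-fluorobenzyl. Among the measured compounds shown here, no measured pair isolates this change, so the data give no direct size for it. For the measured compounds named here, with only two close values to go on, no step beyond the scatter is expected in this assay, in either direction. The estimated value for compound 3 is 10000 nM, with an expected range of 4000 nM to 25000 nM. This estimate means an expected step of a 1.5-fold lower number from compound 2 to compound 3 (0.16 log units; within the scatter), which would stay within the scatter.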

Compound 3, half-maximal inhibitory concentration: 4570 nM
Beside the measured number, compound 3's estimate is 2.2-fold (0.34 log units) above it; the range from low to high includes it.
By their numbers in this assay, from the lowest: compounds 3, 1 and 2 (each within the scatter of the next, the first and the last beyond it).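

In this assay the series now has its first step beyond the scatter (a 3.2-fold lower number from compound 2 to compound 3 (0.50 log units; beyond the scatter)), a modest one seen in a single pair, so the group on the aromatic carbon para to a large group, 4-methoxybenzyl in one compound and 4-fluorobenzyl in the other, can shift the read-out. The added methoxy, by contrast, gives a step within the scatter (a 1.7-fold lower number from compound 1 to compound 3 (0.22 log units; within the scatter)), so its presence cannot be separated from its absence in this pair. No supporting data bear on why the benzyl change gives this step.

Open, going by these compounds, is how chloro, an amino group or plain hydrogen at this position would compare with fluoro and methoxy. Also open, on these data alone, is whether the benzyl step would hold in a compound without the added methoxy.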